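Permeability of Three Measured Compounds and a Fourth Estimated

The source may report more compounds than this note shows. Statements on the series, on what has been measured and on what is new or still open speak of the compounds shown alone.

Three compounds have been measured in an ADME assay for permeability, using PAMPA, at pH 7.4; a lower number here means that the compound crosses the layer more slowly, a higher number that the compound crosses the layer faster:
compound 1, `Cc1cc(NC(=O)Nc2cc(F)ccc2F)c2ccccc2n1`, gives 541 10^-6 cm/s
compound 2, `Cc1cc(NC(=O)Nc2ccccc2C(F)(F)F)c2ccccc2n1`, gives 945 10^-6 cm/s
compound 3, `Cc1cc(NC(=O)Nc2ccccc2F)c2ccccc2n1`, gives 817 10^-6 cm/s

Compound 3 stands second highest of the three numbers. The steps leading to it are a 1.5-fold higher number from compound 1 to compound 3 (0.18 log units; within the scatter) and a 1.2-fold lower number from compound 2 to compound 3 (0.06 log units; within the scatter), both within the scatter, so the three compounds cannot be ordered on these data.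

Compound 4, `Cc1cc(NC(=O)Nc2ccc(Cl)cc2)c2ccccc2n1`, has not yet been measured. It differs from compound 3 in one place: 4-chlorophenyl in place of 2-fluorophenyl on an amide-type nitrogen. The two measured steps, which exchange halogen for hydrogen or for trifluoromethyl on the same aromatic ring, are the ones that bear on this change, and neither moved the number beyond the scatter. Compound 4 is therefore expected to show a 1.0-fold higher number from compound 3 to compound 4 (0.02 log units; within the scatter), no step beyond the scatter. The estimate for compound 4 is 850 10^-6 cm/s, with a range from 450 10^-6 cm/s to 1600 10^-6 cm/s.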

Compound 4, apparent permeability: 537 10^-6 cm/s
Compound 4: the middle estimate sits 1.6-fold (0.20 log units) above what was measured; measured number inside the range.
By their numbers in this assay, from the lowest: compounds 4, 1, 3 and 2 (each within the scatter of the next).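

In this assay, 4-chlorophenyl in place of 2-fluorophenyl on the amide-type nitrogen gives a 1.5-fold lower number from compound 3 to compound 4 (0.18 log units; within the scatter), so exchanging the whole substituted ring, not just one group on it, still does not carry the number beyond the scatter. Across the four compounds, each number remains within the scatter of the next, and no change at this position has separated any neighbouring pair. No measurement shown here accounts for this result. As far as these compounds go, whether an amine or a carboxylic acid on this ring would move the number beyond the scatter stays open, as does the effect of any change to the shared core.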